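The compounds below may be only part of what the source reports. "The series", "measured", "known", "first", "only" and "open" are said of these compounds alone.

The compounds measured so far:
compound 1, `O=C1c2ccccc2N(COCc2ccccc2)S(=O)(=O)N1Cc1ccccc1`, 25000 nM
compound 2, `O=C1c2ccccc2N(Cc2ccccc2Cl)S(=O)(=O)N1Cc1ccccc1Cl`, 40400 nM
compound 3, `O=C1c2ccccc2N(Cc2ccccc2)S(=O)(=O)N1Cc1ccc(Cl)cc1`, 27800 nM

All three share one core and were tested in a functional assay on CCRF-CEM cells (Homo sapiens) for inhibition; a lower number here means that less compound is tolerated, a higher number that more compound is tolerated. In this assay compound 3 gives 27800 nM; on the bare numbers it stands second highest of the three, with compound 1 nearest to it and compound 2 furthest away, yet both of these gaps lie within the usual scatter of repeated measurements, so the three compounds cannot be separated on what has been measured.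

Compound 4, `O=C1c2ccccc2N(Cc2ccccc2)S(=O)(=O)N1Cc1ccccc1`, has not yet been measured. It differs from compound 3 in one place: hydrogen in place of chloro on an aromatic carbon. Going by the values given here, no pair of measured compounds isolates this same change, so there is no direct guide to its size. Among the compounds with values here, what the three measured values do show is that the compounds so far sit close together whatever their substituents, which gives no reason to expect compound 4 to move beyond the scatter in either direction. For compound 4 the step is therefore expected to be small, a 1.0-fold higher number from compound 3 to compound 4 (0.00 log units; within the scatter), with no clear direction. For compound 4 in this assay the estimate is 28000 nM, with a range from 14000 nM to 56000 nM.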

Compound 4, half-maximal cytotoxic concentration: 108000 nM
Compound 4: middle estimate off by 3.9-fold (0.59 log units), on the low side; measured number outside the range, above it.
By their numbers in this assay, from the lowest: compounds 1, 3 and 2 (each within the scatter of the next); then compound 4.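

Taking the chloro off the 4-chlorobenzyl group to leave a benzyl is the first single change in this assay whose size can be read, and it gives a 3.9-fold higher number from compound 3 to compound 4 (0.59 log units; beyond the scatter) on an aromatic carbon that the close earlier values had not shown to matter. The second single change, phenyl in place of benzyloxy on a saturated chain carbon bound to a sulfonamide nitrogen in a ring, gives a 4.3-fold higher number from compound 1 to compound 4 (0.64 log units; beyond the scatter) in the same direction, so compound 4 stands clear of both its single-change neighbours, while the three substituted compounds remain inseparable from one another. Nothing among the available data accounts for either step.

The compounds shown leave open whether a fluoro, a methoxy or an amine at this same place would give a number like that of the chloro or like that of the hydrogen. They also leave open how a longer chain or a carboxylic acid would fare in place of the benzyl groups on the shared core.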